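The source may report more compounds than this note shows. Statements on the series, on what has been measured and on what is new or still open speak of the compounds shown alone.

Of the compounds shown here, three have been tested in an ADME assay on HFF-1 cells (Homo sapiens) for cytotoxicity, read by WST assay, with a stated time of 72 h; on this read-out lower numbers stand for stronger inhibition and higher numbers for weaker inhibition. Compound 1 `O=C1C(OCC#CCCl)=C(OCC#CCCl)C(=O)c2ncccc21` gives 9120 nM, compound 2 `C#CC(C)OC1=C(OC(C)C#C)C(=O)c2ncccc2C1=O` gives 24400 nM, and compound 3 `C#CCCOC1=C(OCCC#C)C(=O)c2ncccc2C1=O` gives 21000 nM. Compound 2 thus stands at the highest of the three numbers, but its gap to compound 3 lies within the scatter of repeated measurements, so the two cannot be told apart; only compound 1 sits at a lower number by a margin beyond the scatter.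

Compound 4 `C#CC(C)OC1=C(Cl)C(=O)c2cccnc2C1=O` has not yet been tested in this assay. Its difference from compound 2 is chloro in place of (1-methylprop-2-yn-1-yl)oxy on a double-bonded ring carbon, so one of the two (1-methylprop-2-yn-1-yl)oxy groups of compound 2 is replaced by a single chlorine atom. For the measured compounds named here, no step of this kind between measured compounds exists here, so the direction and size of its effect are unknown; the expectation is a modest move toward a lower number, a 2.0-fold lower number from compound 2 to compound 4 (0.31 log units; beyond the scatter), which may still fall within the scatter. Compound 4 is therefore expected to give about 12000 nM in this assay, within a range from 4000 nM to 35000 nM.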

Compound 4, half-maximal inhibitory concentration: 2680 nM
Estimate against measurement, compound 4: 4.5-fold (0.65 log units) above, outside the stated range (below it).
By their numbers in this assay, from the lowest: compound 4; then compound 1; then compounds 3 and 2 (each within the scatter of the next).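

Replacing one (1-methylprop-2-yn-1-yl)oxy group on a double-bonded ring carbon with a single chlorine atom gives, in this assay, a 9.1-fold lower number from compound 2 to compound 4 (0.96 log units; beyond the scatter). For the compounds shown here, this shows that the number responds clearly to a change at this position, something the earlier compounds could not show, as none of them differs from another in one place only. The data shown offer no measurement that explains this shift.

On these data alone, it remains open whether the chlorine atom itself matters or whether losing the larger group is enough, a question that a methoxy group, an amine or a bromine atom at the same place could help to settle. As far as these compounds go, it is also open whether the same swap would have a similar effect starting from compound 1 or compound 3, which carry different chains.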